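A few compounds are considered here, and "the series" means these few. Any claim that something is new, unique, unknown or untested is made for them only; others in the source may bear on it.

Of the compounds shown here, three built on one shared core have been measured in a physicochemical assay for solubility, at pH 7.4; on this read-out higher numbers stand for higher solubility and lower numbers for lower solubility. Compound 1 `Cc1cc(Cl)c(-c2cn(C)cn2)cc1NC(=O)c1ccc(OCc2ccccn2)cc1` gives 20000 nM in this assay. Compound 2 `Cc1cc(F)c(-c2ncc[nH]2)cc1NC(=O)c1ccc(OCc2ccccn2)cc1` gives 1000 nM in this assay. Compound 3 `Cc1csc(-c2cc(NC(=O)c3ccc(OCc4ccccn4)cc3)c(C)cc2C)n1` returns < 1000 nM in this assay, which is a limit of the measurement rather than a number, so where compound 3 truly stands is known only as a bound. That bound is the one recorded at the limit of < 1000 nM in this assay, at which 1 of the 3 values shown sits, and it is the only such entry among the three values.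

Compound 4 `Cc1cc(C)c(-c2ccc(N)cn2)cc1NC(=O)c1ccc(OCc2ccccn2)cc1` has not yet been measured in this assay. It is built from compound 3 by a single change: 5-aminopyridin-2-yl in place of 4-methyl-1,3-thiazol-2-yl on an aromatic carbon. Among the measured compounds shown here, no pair of measured compounds differs in exactly this way, so there is no measured step to lean on, and what follows is an expectation only. Compound 4 is expected to give about 3000 nM in this assay, with a plausible range from 600 nM to 15000 nM. That estimate amounts to an expected step of an at least 3.0-fold higher number from compound 3 to compound 4 (0.47 log units; beyond the scatter), a rise larger than the usual scatter, though it may still land at the same limit that compound 3 reached.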

Compound 4, solubility: < 1000 nM
Compound 4 was reported as a limit; the forecaster's own chance of this, stated with the estimate: 30%; at least 3.0-fold (0.47 log units) between middle value and limit.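

Compound 3 and compound 4 both sit at a limit of the measurement rather than at a number, so no step between them can be read: the limit of < 1000 nM in this assay, at which 2 of the 4 values shown sit.

Where each of the two compounds truly stands, and whether 5-aminopyridin-2-yl in place of 4-methyl-1,3-thiazol-2-yl shifts the read-out at all, stays open.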